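The compounds below may be only part of what the source reports. "The series", "measured", "known", "first", "only" and "open" are said of these compounds alone.

Working notes on the oxadiazolone series.

Three compounds carry numbers in a functional assay on the whole organism (strain Wistar albino) for inhibition, with Rattus norvegicus as the target, read by paw edema, with stated times of 30 min and 2 h, at a dose of 10 mg/kg by the oral route; on this read-out higher numbers stand for more inhibition at the one dose given (going by the name of the read-out) and lower numbers for less inhibition. The parent with hydrogen on the aromatic nitrogen, compound 1 `COc1ccc(F)cc1-c1cccc(-c2n[nH]c(=O)o2)c1`, gives 56% in this assay. Compound 2 `COc1ccc(F)cc1-c1cccc(-c2nn(CCCCF)c(=O)o2)c1` gives 83%, and compound 3 `COc1ccc(F)cc1-c1cccc(-c2nn(CCO)c(=O)o2)c1` gives 69%. Substitution on the aromatic nitrogen has raised the number in both cases so far: 4-fluorobutyl in place of hydrogen gives a number 27 percentage points higher from compound 1 to compound 2 (beyond the scatter), and 2-hydroxyethyl in place of hydrogen gives a number 13 percentage points higher from compound 1 to compound 3 (beyond the scatter). Between the two substituted compounds, hydroxy in place of 2-fluoroethyl on the chain gives a number 14 percentage points lower from compound 2 to compound 3 (beyond the scatter). Compound 2 thus stands highest of the three, with compound 3 nearest and compound 1 furthest behind it, both gaps beyond the scatter.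

The next compound, compound 4 `COc1ccc(F)cc1-c1cccc(-c2nn(CCCN)c(=O)o2)c1`, keeps the chain on the aromatic nitrogen but changes its end: amino in place of fluoromethyl on a saturated chain carbon, three bonds along the chain from an aromatic nitrogen. Within the data shown here, the bearing step is the one from compound 2 to compound 3, where a group with a hydrogen-bond donor and acceptor replaced a fluorine-bearing chain end and the number fell modestly. The steps from compound 1 show the substituted nitrogen itself should keep compound 4 above the parent. A modest downward step from compound 2 is therefore expected for compound 4, a number 13 percentage points lower from compound 2 to compound 4 (beyond the scatter), with compound 4 estimated at 70% in this assay, within the range 56% to 84%.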

Compound 4, a percentage reported as inhibition, in the whole organism at one dose (the size of the read-out at that dose, not a potency): 66%
Beside the measured number, compound 4's estimate is 4 percentage points above it, within the range that was stated.
By their numbers in this assay, from the lowest: compounds 1, 4 and 3 (each within the scatter of the next, the first and the last beyond it); then compound 2.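

Compound 4 goes against the rise seen with substitution on the aromatic nitrogen: in this assay the 3-aminopropyl chain gives a number 10 percentage points higher from compound 1 to compound 4 (within the scatter), so this chain cannot be told from the hydrogen of the parent, unlike 4-fluorobutyl and 2-hydroxyethyl. Among these compounds, at the chain end, the change from fluoromethyl to amino costs as much as a step that is clear of the noise, a number 17 percentage points lower from compound 2 to compound 4 (beyond the scatter), and so compound 2 remains the only compound here clearly above all the others, while the amino-ended and hydroxy-ended chains stay together, a number 3 percentage points lower from compound 3 to compound 4 (within the scatter). Nothing available on these compounds bears on why the chain end matters at this position.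

Chain length and chain end change together from compound 3 to compound 4, so a 3-hydroxypropyl or 2-aminoethyl chain would be needed to part the two. On these data alone, whether the fluorine itself carries the higher number of compound 2 stays open as well, and a plain butyl chain or a chain ending in a carboxylic acid would test that.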